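Phenoxy for phenyl at the limit of a cell assay

The compounds below may be only part of what the source reports. "The series", "measured", "known", "first", "only" and "open" are said of these compounds alone.

In an ADME assay on HepG2 cells (Homo sapiens) for cytotoxicity, read by luminescence, with a stated time of 72 h (a lower number here means that less compound is needed, a higher number that more compound is needed for the effect), compound 2 (`CCOC(=O)c1c(-c2cccc(-c3ccccc3)c2)[nH]c2cc(O)ccc2c1=O`) gives > 21500 nM as a limit of the assay and not as a number. Compound 1 (`CCOC(=O)c1c(-c2cccc(Oc3ccccc3)c2)[nH]c2cc(OC)ccc2c1=O`) gives > 21500 nM and this too is only a limit. The whole picture so far is the limit of > 21500 nM in this assay, at which 2 of the 2 values shown sit, and no true number exists yet for either compound.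

Compound 3 (`CCOC(=O)c1c(-c2cccc(Oc3ccccc3)c2)[nH]c2cc(O)ccc2c1=O`) is still unmeasured. It has phenoxy in place of phenyl on an aromatic carbon, meta to a large group (phenoxy in place of phenyl on an aromatic carbon). Going by the values given here, no measured step shows what this swap does, so in this assay no step beyond the usual scatter is expected, and another limit is the likeliest report.

Among the compounds with values here, compound 2 anchors that expectation, with its > 21500 nM as the only guide and a limit rather than a number. Estimated from that limit, the expected step (a step that the limit leaves unreadable from compound 2 to compound 3) stays small. If a number does appear, compound 3 is estimated at 25000 nM with an expected range from 12000 nM to 50000 nM for the measurement.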

Compound 3, half-maximal effective concentration: > 21500 nM
Compound 3 gave a limit, no number; the forecaster's own chance of this, stated with the estimate: 80%; the middle value lies beyond the limit too.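

Compound 3 gives > 21500 nM in this assay, which is a limit and not a number. No step can be read from compound 2 to compound 3 or from compound 1 to compound 3. Whether either swap changes the concentration needed for the effect remains open, and the whole picture is still a single ceiling: the limit of > 21500 nM in this assay, at which 3 of the 3 values shown sit.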